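Replacing aminomethyl on the shared core: estimate for compound 4

The source may report more compounds than this note shows. Statements on the series, on what has been measured and on what is new or still open speak of the compounds shown alone.

Measured compounds:
Compound 1 `CNC(=N)Nc1nc(-c2ccc(OC)cc2)c(-c2ccc(OC)cc2)s1` gives 62 nM in a functional assay with Oryctolagus cuniculus as the target; a higher number here means a weaker inhibitor, a lower number a stronger inhibitor.
Compound 2 `COc1ccc(-c2nc(CNC(C)=O)sc2-c2ccc(OC)cc2)cc1` gives 15 nM in this assay.
Compound 3 `COc1ccc(-c2nc(CN)sc2-c2ccc(OC)cc2)cc1` gives only a limit, > 100 nM, in this assay.

Going by the values given here, compound 3 is the one compound of the three whose result is a limit rather than a number (the limit of > 100 nM in this assay, at which 1 of the 3 values shown sits). The measured steps that lead to it are an at least 1.6-fold higher number from compound 1 to compound 3 (0.20 log units; that floor lies within the scatter) and an at least 6.6-fold higher number from compound 2 to compound 3 (0.82 log units; beyond the scatter), so compound 3 sits at the weak end of what has been measured.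

Compound 4 `COc1ccc(-c2nc(C(=O)N=C(N)N)sc2-c2ccc(OC)cc2)cc1` differs from compound 3 as follows: a group of 6 heavy atoms (2 carbon, 3 nitrogen, 1 oxygen; no ring) in place of a group of 2 heavy atoms (1 carbon, 1 nitrogen; no ring), on an aromatic carbon.

Among the compounds with values here, two measured steps bear on this. a 4.1-fold lower number from compound 1 to compound 2 (0.62 log units; beyond the scatter) shows that a group holding an oxygen in place of a nitrogen-rich group at this aromatic carbon gave a lower number. an at least 6.6-fold higher number from compound 2 to compound 3 (0.82 log units; beyond the scatter) shows that stripping the substituent down to aminomethyl raised the number past the limit. Compound 4 restores a larger group at the same aromatic carbon, carrying both nitrogens and an oxygen, so the number for compound 4 is expected to fall back into the range of compound 1 and compound 2, giving an expected at least 2.5-fold lower number from compound 3 to compound 4 (0.39 log units; beyond the scatter).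

The estimate for compound 4 in this assay is 40 nM, with a range from 12 nM to 150 nM.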

Compound 4, half-maximal inhibitory concentration: > 100 nM
Compound 4 gave a limit, no number (the forecaster's own chance of this, stated with the estimate: 25%); middle value at least 2.5-fold (0.39 log units) away from the limit.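

In this assay compound 4 , with its larger group on the aromatic carbon next to the ring nitrogen and next to the ring sulfur, gives only a limit, > 100 nM, and the step between compound 3 and compound 4 cannot be read, so this limit now holds two compounds of the series: the limit of > 100 nM in this assay, at which 2 of the 4 values shown sit. Against the acetyl-capped side chain, the new group gives an at least 6.6-fold higher number from compound 2 to compound 4 (0.82 log units; beyond the scatter), so at this position a larger group carrying a carbonyl does not by itself reproduce the low number of compound 2 . The comparison with the other nitrogen-rich group, an at least 1.6-fold higher number from compound 1 to compound 4 (0.20 log units; that floor lies within the scatter), has a floor within the scatter and does not separate those two compounds.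

Going by these compounds, how far compound 3 and compound 4 lie beyond the limit remains open, and with it any order between them. Also open, on these data alone, is whether the low number of compound 2 depends on the acetyl group or on the methylene that carries the amide nitrogen, a question that a longer acyl chain or a carboxylic acid on the same aromatic carbon would bear on.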